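The source may report more compounds than this note shows. Statements on the series, on what has been measured and on what is new or still open speak of the compounds shown alone.

Measured compounds:
compound 1 `c1ccc(-c2cccc(Cn3ccnc3)c2)cc1` — 38%
compound 2 `c1ccc(-c2cc(Cn3ccnc3)cc(-c3ccccc3)c2)cc1` — 12%

Among the two compounds measured in an assay for inhibition of Aromatase (Homo sapiens), using microsomes, tested at 500 nM (a higher number here means more inhibition at the concentration tested (going by the name of the read-out), a lower number less inhibition), compound 1 stands highest, with compound 2 the only neighbour and a number 26 percentage points lower from compound 1 to compound 2 (beyond the scatter), a modest drop that goes beyond the scatter. Compound 3 `Cc1cccc(Cn2ccnc2)c1` is not yet measured; it differs from compound 1 in one place: methyl in place of phenyl on an aromatic carbon. Among the measured compounds shown here, only one measured step exists, and it does not cover this change: it shows what happens when a phenyl is added to the shared core, not when the phenyl of compound 1 is exchanged for a methyl. That step was a lowering of modest size, so more aromatic bulk did not help here, but nothing shows how a smaller group fares. The expectation for compound 3 is therefore a step of uncertain direction and probably within the scatter, a number 13 percentage points lower from compound 1 to compound 3 (beyond the scatter). The estimate for compound 3 in this assay is 25%, expected to lie between 5% and 50%.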

Compound 3, a percentage reported as inhibition, at one concentration (the size of the read-out at that concentration, not a potency): 12%
Beside the measured number, compound 3's estimate is 13 percentage points above it, within the range that was stated.
By their numbers in this assay, from the lowest: compounds 2 and 3 (each within the scatter of the next); then compound 1.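

Exchanging the phenyl for a methyl, on the aromatic carbon meta to a (1H-imidazol-1-yl)methyl group, gives in this assay a number 26 percentage points lower from compound 1 to compound 3 (beyond the scatter) and so marks this position as sensitive to the change. The earlier step showed only that adding a further phenyl went with less inhibition, whereas here the much smaller methyl, one carbon in place of six, also gives less inhibition, so a smaller group does not by itself restore the number. No measurement on hand explains why the number is higher with the phenyl than with the methyl here.

Still open, as far as these compounds go, is how a plain hydrogen at this position would compare. Also open, from the compounds shown here alone, is how an ethyl chain, a methoxy group or an amine would fare there.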